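A few compounds are considered here, and "the series" means these few. Any claim that something is new, unique, unknown or untested is made for them only; others in the source may bear on it.

Two compounds of the series have so far been run in an ADME assay on HEK293 cells (Homo sapiens) for cytotoxicity, read by MTT assay, with a stated time of 44 h; a lower number here means a stronger inhibitor, a higher number a weaker inhibitor. Compound 1 `CCC1(c2cccc(Br)c2)ON=C(c2ccccc2Cl)O1` sits at the assay limit: in this assay compound 1 gives > 100000 nM, a limit rather than a number. Compound 2 `CC1(c2cccc(Br)c2)ON=C(c2ccc(Cl)cc2)O1` stands in the same place; in this assay compound 2 gives > 100000 nM, again a limit and not a measured number. Both values shown thus sit at the limit of > 100000 nM in this assay, at which 2 of the 2 values shown sit, so compound 2 cannot be ordered against compound 1. Compound 3 `CCC1(c2cccc(Br)c2)ON=C(c2ccc(Cl)cc2)O1` differs from compound 2 by methyl in place of hydrogen on a saturated chain carbon bound to a saturated ring carbon. Compound 1 carries the ethyl chain and also sits at the limit. Going by the values given here, no step between measured compounds exists here, so no step beyond the scatter is expected from compound 2 to compound 3 in this assay, and compound 3 is expected to remain at the limit. Compound 3 is estimated at 100000 nM, within 50000 nM to 200000 nM. The expected step is a number no higher from compound 2 to compound 3 (the limit leaves the size open).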

Compound 3, half-maximal inhibitory concentration: > 100000 nM
Compound 3 gave a limit, no number; the forecaster's own chance of this, stated with the estimate: 85%; the middle value sits exactly at the limit.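

No new step can be read in this assay: the pairs of compound 3 with compound 2 and with compound 1 both end in limits, not numbers: the limit of > 100000 nM in this assay, at which 3 of the 3 values shown sit.

The compounds shown leave open whether methyl in place of hydrogen, or 4-chlorophenyl in place of 2-chlorophenyl, changes the read-out at all.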